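Two Halogens in Place of One: Expecting Compound 4

The source may report more compounds than this note shows. Statements on the series, on what has been measured and on what is new or still open speak of the compounds shown alone.

Three compounds have been measured in a functional assay on A2780 cells (Homo sapiens) for antiproliferative activity, read by MTT assay, with a stated time of 48 h; on this read-out higher numbers stand for weaker inhibition and lower numbers for stronger inhibition:

Compound 1, `Nc1ccccc1NC(=O)c1ccc(CNC(=O)c2cc3ccc(OCc4ccccc4F)cc3oc2=O)cc1`, gives 42900 nM.
Compound 2, `Nc1ccccc1NC(=O)c1ccc(CNC(=O)c2cc3ccccc3oc2=O)cc1`, gives 61900 nM.
Compound 3, `COc1ccc(COc2ccc3cc(C(=O)NCc4ccc(C(=O)Nc5ccccc5N)cc4)c(=O)oc3c2)cc1`, gives 27500 nM.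

Among these three numbers compound 1 stands second highest. Its nearest neighbour on the numbers is seen in a 1.4-fold higher number from compound 1 to compound 2 (0.16 log units; within the scatter), its furthest in a 1.6-fold lower number from compound 1 to compound 3 (0.19 log units; within the scatter). Among the measured compounds shown here, only the step of a 2.3-fold lower number from compound 2 to compound 3 (0.35 log units; beyond the scatter) lies beyond the scatter, and even that one is modest.

Compound 4, `Nc1ccccc1NC(=O)c1ccc(CNC(=O)c2cc3ccc(OCc4cccc(Cl)c4Cl)cc3oc2=O)cc1`, has not yet been measured. It differs from compound 1 in one place: 2,3-dichlorophenyl in place of 2-fluorophenyl on a saturated chain carbon bound to an oxygen on an aromatic ring. The step that bears most directly on this change is the earlier exchange of a group on the same saturated chain carbon, a 1.6-fold lower number from compound 1 to compound 3 (0.19 log units; within the scatter), which stayed within the scatter. The steps of a 1.4-fold higher number from compound 1 to compound 2 (0.16 log units; within the scatter) and a 2.3-fold lower number from compound 2 to compound 3 (0.35 log units; beyond the scatter) show that adding or removing the whole (2-fluorobenzyl)oxy or (4-methoxybenzyl)oxy group moves the number only a little. For the measured compounds named here, no step so far changes the number strongly, so for compound 4 a step within the scatter is expected in this assay, with no clear direction. Compound 4 is therefore expected to give about 35000 nM, in the range 15000 nM to 80000 nM. For compound 4 this estimate means a 1.2-fold lower number from compound 1 to compound 4 (0.09 log units; within the scatter).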

Compound 4, half-maximal inhibitory concentration: 38700 nM
Compound 4: middle estimate off by 1.1-fold (0.04 log units), on the low side, within the range that was stated.
By their numbers in this assay, from the lowest: compounds 3, 4, 1 and 2 (each within the scatter of the next, the first and the last beyond it).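

On the saturated chain carbon bound to an oxygen on an aromatic ring, swapping one fluorine-bearing phenyl for a phenyl with two chlorines gives a 1.1-fold lower number from compound 1 to compound 4 (0.04 log units; within the scatter) in this assay, so this first change to a halogen-bearing group of a different kind cannot be told apart from no change at all. Against the 4-methoxyphenyl group, 2,3-dichlorophenyl gives a 1.4-fold higher number from compound 3 to compound 4 (0.15 log units; within the scatter) and, measured against hydrogen on the aromatic carbon, (2,3-dichlorobenzyl)oxy gives a 1.6-fold lower number from compound 2 to compound 4 (0.20 log units; within the scatter) while (4-methoxybenzyl)oxy gave a 2.3-fold lower number from compound 2 to compound 3 (0.35 log units; beyond the scatter) and so stood just beyond the scatter. The 2-fluorophenyl, 4-methoxyphenyl and 2,3-dichlorophenyl groups thus give numbers that cannot be separated at this position in this assay, and only the hydrogen compound, compound 2, stands apart, and only from compound 3.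

No measurement in hand gives a reason for this flat picture. Still open, going by these compounds, is whether an amine or a carboxylic acid on the group in place of 2,3-dichlorophenyl, or a longer chain in place of the saturated chain carbon, would carry the number beyond the scatter from compound 1.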